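A Thioether Swap in a Retinaldehyde Dehydrogenase 3 Series

The source may report more compounds than this note shows. Statements on the series, on what has been measured and on what is new or still open speak of the compounds shown alone.

Of the compounds shown here, three have been measured in an assay on isolated protein for inhibition of Retinaldehyde dehydrogenase 3 (Homo sapiens); a lower number here means a stronger inhibitor, a higher number a weaker inhibitor. Compound 1 `CC(Oc1nc2c(cnn2C)c(=O)n1-c1ccccc1)c1ccccc1` gives 600 nM, and compound 3 `Cn1ncc2c(=O)n(-c3ccccc3)c(SCc3cccc(F)c3)cc21` gives 140 nM. Compound 2 `Cn1ncc2c(=O)n(-c3ccccc3)c(SC(C)(C)c3ccccc3)nc21` gives 1390 nM, the highest of the three numbers, and both gaps to the others lie beyond the usual scatter, so compound 2 is the weakest inhibitor measured so far.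

Compound 4 `CC(Sc1nc2c(cnn2C)c(=O)n1-c1ccccc1)c1cncnc1` differs from compound 2 in one place: 1-(pyrimidin-5-yl)ethyl in place of 1-methyl-1-phenylethyl on a sulfur

For the measured compounds named here, no measured pair shows this change directly, so any expectation rests only on the spread of the three numbers. Compound 4 is expected to land near 700 nM, with a likely range from 250 nM to 2500 nM. The expected step is a modest decrease a 2.0-fold lower number from compound 2 to compound 4 (0.30 log units; within the scatter), close to the edge of the scatter rather than a large shift.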

Compound 4, half-maximal inhibitory concentration: 100 nM
Compound 4: middle estimate off by 7.0-fold (0.85 log units), on the high side; the measured number lies below the stated range.
By their numbers in this assay, from the lowest: compounds 4 and 3 (each within the scatter of the next); then compound 1; then compound 2.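

For the compounds shown here, the group on this sulfur matters a great deal in this assay: replacing 1-methyl-1-phenylethyl with 1-(pyrimidin-5-yl)ethyl gives a 14-fold lower number from compound 2 to compound 4 (1.14 log units; beyond the scatter), a size of effect that the earlier compounds, with no one-place pair among them, could not reveal. The swap changes the ring and also removes a methyl group, and nothing measured here explains the step. As far as these compounds go, it remains open whether the ring or the methyl group accounts for the change. A plain 1-phenylethyl group on the sulfur would separate the two.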